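Swapping the para substituent on a chromone-like core

A few compounds are considered here, and "the series" means these few. Any claim that something is new, unique, unknown or untested is made for them only; others in the source may bear on it.

Measured so far:
- compound 1 `CCC1=C(O)c2c(oc(-c3ccc(CC(C)C)cc3)cc2=O)C(CC)(CC)C1=O`: 17.4 uM
- compound 2 `CCCOc1ccc(-c2cc(=O)c3c(o2)C(CC)(CC)C(=O)C(CC)=C3O)cc1`: 29.2 uM
- compound 3 `CCC1=C(O)c2c(oc(-c3ccc(SC)cc3)cc2=O)C(CC)(CC)C1=O`: 1.38 uM

In a functional assay on KBVIN cells (Homo sapiens) for antiproliferative activity, read by sulforhodamine B assay, with a stated time of 3 days (a lower number here means that less compound is needed, a higher number that more compound is needed for the effect), compound 1 stands second highest of the three numbers, close to compound 2 and far from compound 3. The next compound, compound 4 `CCC1=C(O)c2c(oc(-c3ccc(F)cc3)cc2=O)C(CC)(CC)C1=O`, is not yet measured; it differs from compound 1 by fluoro in place of isobutyl on an aromatic carbon. Two measured steps start from the same isobutyl group: a 1.7-fold higher number from compound 1 to compound 2 (0.22 log units; within the scatter), and a 13-fold lower number from compound 1 to compound 3 (1.10 log units; beyond the scatter). For the measured compounds named here, one replacement left the number unchanged, the other lowered it sharply, so the outcome of changing this group is not settled by these data, and the fluoro group has no measured counterpart. A modest shift is therefore expected, as a 1.7-fold lower number from compound 1 to compound 4 (0.24 log units; within the scatter). Compound 4 is estimated at 10 uM, within 2.5 uM to 40 uM.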

Compound 4, concentration for half-maximal effect: 1.85 uM
Beside the measured number, compound 4's estimate is 5.4-fold (0.73 log units) above it, and the stated range ends above it.
By their numbers in this assay, from the lowest: compounds 3 and 4 (each within the scatter of the next); then compounds 1 and 2 (each within the scatter of the next).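

In this assay, fluoro and methylsulfanyl at this position give numbers within the scatter of each other, with a 1.3-fold higher number from compound 3 to compound 4 (0.13 log units; within the scatter), so a low number here does not depend on the sulfur of compound 3. Replacing the larger groups with a single fluorine atom gives a 9.4-fold lower number from compound 1 to compound 4 (0.97 log units; beyond the scatter) and a 16-fold lower number from compound 2 to compound 4 (1.20 log units; beyond the scatter), which separates both isobutyl and propoxy from two different replacements. Nothing measured here gives a reason for this split. From the compounds shown here alone, whether chloro, an amine or a carboxylic acid at the same place would also give a low number remains open. So does the effect of a longer chain on the sulfur.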